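The source may report more compounds than this note shows. Statements on the series, on what has been measured and on what is new or still open speak of the compounds shown alone.

Working notes on the series, read in a functional assay on MCF7 cells (Homo sapiens) for cytotoxicity, read by MTT assay, with a stated time of 72 h; on this read-out higher numbers stand for weaker inhibition and lower numbers for stronger inhibition.

Measured so far:
compound 1, `COc1cc(-c2ccc(C)n2-c2ccc(-c3nc4ccccc4s3)cc2)cc(OC)c1OC`, gives 4370 nM in this assay;
compound 2, `COc1ccc(-c2ccc(C)n2-c2ccc(-c3nc4ccc(F)cc4s3)cc2)cc1`, gives 2550 nM;
compound 3, `COc1cc(-c2ccc(C)n2-c2ccc(-c3nc4ccc(F)cc4s3)cc2)cc(OC)c1OC`, gives 2360 nM.

Compound 3 holds the lowest of the three numbers, yet the spread is small: compound 2 sits within the scatter of compound 3, and compound 1 sits within the scatter as well. Within the data shown here, the only single-point step available in the set is a 1.9-fold lower number from compound 1 to compound 3 (0.27 log units; within the scatter), and it too stays inside the scatter. No ordering among the three compounds is therefore established by these numbers.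

Compound 4, `COc1ccc2nc(-c3ccc(-n4c(C)ccc4-c4cc(OC)c(OC)c(OC)c4)cc3)sc2c1`, differs from compound 3 by methoxy in place of fluoro on an aromatic carbon. Among the measured compounds shown here, no measured pair in the set carries a methoxy at this position, so the change is without a direct precedent here. For the measured compounds named here, the one related step, a 1.9-fold lower number from compound 1 to compound 3 (0.27 log units; within the scatter), concerns the fluoro that now leaves and was itself within the scatter. On that basis a step beyond the scatter is not expected in this assay in either direction; the expected step from compound 3 is a 1.1-fold higher number from compound 3 to compound 4 (0.03 log units; within the scatter). Compound 4 is accordingly estimated at 2500 nM, with a range of 1000 nM to 6500 nM.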

Compound 4, half-maximal inhibitory concentration: 1520 nM
Estimate against measurement, compound 4: 1.6-fold (0.22 log units) above; the range from low to high includes it.
By their numbers in this assay, from the lowest: compounds 4, 3, 2 and 1 (each within the scatter of the next, the first and the last beyond it).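

Methoxy on this aromatic carbon gives the first step in the series that clears the usual scatter in this assay: with hydrogen as the starting point, the step is a 2.9-fold lower number from compound 1 to compound 4 (0.46 log units; beyond the scatter) and is modest in size. Fluoro as the starting point gives a different reading, a 1.6-fold lower number from compound 3 to compound 4 (0.19 log units; within the scatter), so methoxy and fluoro are not separated at this position, and the change from hydrogen is the only one here that can be read as a real difference. Nothing available bears on what lies behind this step.

Among these compounds, it remains open whether an ethoxy, a hydroxyl or an amine at the same aromatic carbon would extend the step, hold it or reverse it, since the series so far offers only hydrogen, fluoro and methoxy there. From the compounds shown here alone, it is also open whether the change to 6-methoxy-1,3-benzothiazol-2-yl would read the same way with the differently substituted aryl group of compound 2, which has no methoxy partner at this position.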